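A few compounds are considered here, and "the series" means these few. Any claim that something is new, unique, unknown or untested is made for them only; others in the source may bear on it.

Measured compounds:
compound 1, `CCC(=O)N1N=C(c2ccccc2)CC1c1ccc(Cl)cc1`: 100000 nM
compound 2, `CCC(=O)N1N=C(c2ccc(Cl)cc2)CC1c1ccc(Cl)cc1`: 10000 nM
compound 3, `CCC(=O)N1N=C(c2ccc(F)cc2)CC1c1ccccc1`: 200 nM

In an assay on isolated protein for inhibition of Amine oxidase [flavin-containing] B (Bos taurus) (a higher number here means a weaker inhibitor, a lower number a stronger inhibitor), compound 3 gives the lowest of the three numbers; compound 2 sits at 10000 nM and compound 1 at 100000 nM, both far higher than compound 3 by more than the usual scatter.

Compound 4, `CCC(=O)N1N=C(c2ccc(F)cc2)CC1c1ccc(C)cc1`, differs from compound 3 in one place: methyl in place of hydrogen on an aromatic carbon. The only measured single step among these compounds is a different substituent at an aromatic carbon: a 10-fold lower number from compound 1 to compound 2 (1.00 log units; beyond the scatter). That step lowered the number, but it put a chloro rather than a methyl onto a ring, so it bears on the present change only loosely. Among the compounds with values here, no measured pair shows a methyl for hydrogen swap. A small substituent on an aromatic ring here changed the number in a modest way in the one case on record, so the expectation for compound 4 is a step of similar or smaller size, most likely downward, and possibly within the scatter.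

The estimate for compound 4 in this assay is 120 nM, with a range from 40 nM to 400 nM, which corresponds to an expected 1.7-fold lower number from compound 3 to compound 4 (0.22 log units; within the scatter).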

Compound 4, half-maximal inhibitory concentration: 151 nM
The estimate for compound 4 lay 1.3-fold (0.10 log units) below the measured number, and the stated range covers the measured number.
By their numbers in this assay, from the lowest: compounds 4 and 3 (each within the scatter of the next); then compound 2; then compound 1.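

Within the data shown here, the first direct reading of this position comes from swapping hydrogen for methyl, para to a large group on the six-membered aromatic ring: in this assay, the swap gives a 1.3-fold lower number from compound 3 to compound 4 (0.12 log units; within the scatter). A step of this size cannot be told apart from repeat-measurement noise, so this position accepts a methyl without a measurable loss or gain, and compound 4 remains an inhibitor on the same footing as compound 3. Among these compounds, the one earlier step showed a clear shift from a single added chloro, whereas this change shows that adding a substituent to an aromatic carbon need not move the number at all, although nothing at hand explains the result.

From the compounds shown here alone, a single methyl says little about how much room for change this position offers, so it remains open whether a longer chain such as propyl, an amine or a carboxylic acid placed there would leave the number equally undisturbed. Going by these compounds, it is also open whether methyl would behave the same way on a partner lacking the fluoro group of compound 4.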